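Chlorine on the anilino ring: two cores, one change

The compounds below may be only part of what the source reports. "The series", "measured", "known", "first", "only" and "open" are said of these compounds alone.

Measured in a functional assay on A-375 cells (Homo sapiens) for antiproliferative activity, read by CCK-8 assay, with a stated time of 72 h; on this read-out higher numbers stand for weaker inhibition and lower numbers for stronger inhibition:
compound 1 `Nc1ccccc1NC(=O)c1ccc(Cn2cnc3c(Nc4ccccc4)nc(Cl)nc32)cc1` gives 2800 nM
compound 2 `CCCCn1cnc2c(Nc3ccccc3)nc(NCOCc3ccc(C(=O)Nc4ccccc4N)cc3)nc21` gives 4480 nM
compound 3 `Nc1ccccc1NC(=O)c1ccc(Cn2cnc3c(Nc4cccc(Cl)c4)nc(Cl)nc32)cc1` gives 6080 nM

Compounds 1 and 3 share one core and differ at a single place, (chloro in place of hydrogen on an aromatic carbon), a change that gave a 2.2-fold higher number from compound 1 to compound 3 (0.34 log units; beyond the scatter). Compound 2 has a different core; the difference between the two cores is not broken down here, and the two values simply stand as given. Compound 4 `CCCCn1cnc2c(Nc3cccc(Cl)c3)nc(NCOCc3ccc(C(=O)Nc4ccccc4N)cc3)nc21` has not yet been measured in this assay. It differs from compound 2 by chloro in place of hydrogen on an aromatic carbon, the same change as between compound 1 and compound 3, at a place described in the same words, so this change occurs in two pairs of compounds here. Because compound 1 to compound 3 moved by a 2.2-fold higher number from compound 1 to compound 3 (0.34 log units; beyond the scatter), a step of similar direction and size is expected from compound 2 to compound 4, estimated as a 1.9-fold higher number from compound 2 to compound 4 (0.28 log units; within the scatter). On that basis compound 4 is expected to give about 8500 nM in this assay, most likely between 4500 nM and 18000 nM.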

Compound 4, half-maximal inhibitory concentration: 6820 nM
Estimate against measurement, compound 4: 1.2-fold (0.10 log units) above, and the stated range covers the measured number.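

In this assay, among the compounds shown here, the change from phenyl to 3-chlorophenyl on the core of compound 2 gives a 1.5-fold higher number from compound 2 to compound 4 (0.18 log units; within the scatter) and so, taken alone, is no step that stands clear of the scatter. Read together, the two steps on the two cores cannot be told apart, and nothing here shows the change behaving differently from one core to the other: the same change on two cores in this assay, a 2.2-fold higher number (0.34 log units; beyond the scatter) from compound 1 to compound 3 and a 1.5-fold higher number (0.18 log units; within the scatter) from compound 2 to compound 4, 1.4-fold (0.15 log units) apart, within the scatter of two such steps. For the compounds shown here, this supports carrying the chloro step across these two cores as a rough guide, but it rests on two pairs in a single cell assay, only one of the steps lies beyond the scatter, and it does not show that the step would hold on any further core.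

As far as these compounds go, whether a fluoro or a methoxy group at the same place on the anilino ring would give a step like that of chloro remains open. So does whether the step would survive on a core carrying a longer chain in place of the butyl group of compound 2.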